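Trading a fused aromatic group for a cyclohexenylmethyl chain

A few compounds are considered here, and "the series" means these few. Any claim that something is new, unique, unknown or untested is made for them only; others in the source may bear on it.

In a functional assay on Jurkat cells for inhibition of nuclear factor NF-kappa-B complex (Homo sapiens) (on this read-out lower numbers stand for stronger inhibition and higher numbers for weaker inhibition), compound 3 `CCOC(=O)c1cnc(-c2cc3ccccc3s2)nc1NN1C(=O)C=C(C)C1=O` gives 4000 nM. Among the three measured compounds it holds the second highest number: compound 2 `CCOC(=O)c1cnc(-c2cccc([N+](=O)[O-])c2)nc1NN1C(=O)C=C(C)C1=O` gives 7000 nM, and the difference a 1.8-fold lower number from compound 2 to compound 3 (0.24 log units; within the scatter) lies within the scatter, whereas compound 1 `CCOC(=O)c1cnc(-c2ccccc2)nc1NN1C(=O)C=C(C)C1=O` gives 100 nM, so that the step of a 40-fold higher number from compound 1 to compound 3 (1.60 log units; beyond the scatter) lies far beyond it.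

Compound 4 `CCOC(=O)c1cnc(CC2=CCCCC2)nc1NN1C(=O)C=C(C)C1=O` has not yet been measured in this assay. It carries the change ((cyclohex-1-en-1-yl)methyl in place of 1-benzothiophen-2-yl on an aromatic carbon). Going by the values given here, no measured step exchanges an aromatic group for a non-aromatic one at this position, so none bears on it directly. The steps that come closest are a 40-fold higher number from compound 1 to compound 3 (1.60 log units; beyond the scatter) and a 70-fold higher number from compound 1 to compound 2 (1.85 log units; beyond the scatter), both large, which show that replacing the phenyl of compound 1 moves the read-out strongly; the step of a 1.8-fold lower number from compound 2 to compound 3 (0.24 log units; within the scatter), by contrast, shows two such replacements landing close together. On this basis the number for compound 4 is expected to stay near that of compound 3, with wide uncertainty. The step of no change at the digits printed from compound 3 to compound 4 (within the scatter) is thus expected to be small relative to the scatter. Compound 4 is therefore estimated to give about 4000 nM in this assay, within a range from 500 nM to 40000 nM.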

Compound 4, half-maximal inhibitory concentration: 2000 nM
For compound 4 the middle estimate is 2.0-fold (0.30 log units) above the measured one; measured number inside the range.
By their numbers in this assay, from the lowest: compound 1; then compounds 4, 3 and 2 (each within the scatter of the next, the first and the last beyond it).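

In this assay, (cyclohex-1-en-1-yl)methyl is the only group shown at this position without an aromatic ring, yet a 2.0-fold lower number from compound 3 to compound 4 (0.30 log units; within the scatter) leaves it level with 1-benzothiophen-2-yl, so among these compounds an aromatic ring in the group does not by itself set the number. Neither does the absence of one restore the strength of the unsubstituted phenyl: a 20-fold higher number from compound 1 to compound 4 (1.30 log units; beyond the scatter) is a large step, comparable in kind to those away from phenyl to the two aromatic replacements, while a 3.5-fold lower number from compound 2 to compound 4 (0.54 log units; beyond the scatter) is a modest step that sets the new group apart from 3-nitrophenyl. No measurement is available that would explain any of these steps.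

The compounds shown leave open whether the low number of compound 1 depends on a phenyl attached directly to the aromatic carbon, which a benzyl group or a cyclohexyl group at the same place would test. From the compounds shown here alone, it also remains open how far small groups on that phenyl, such as a methyl, a methoxy or a fluorine, are accepted, and whether a carboxylic acid or an amide could stand in place of the ethoxycarbonyl group.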